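Working notes: from compound 2 to the methyl analogue compound 4

The compounds below may be only part of what the source reports. "The series", "measured", "known", "first", "only" and "open" are said of these compounds alone.

Measured in a functional assay on L1210 cells (Mus musculus) for cytotoxicity, with a stated time of 48 h; a higher number here means a weaker inhibitor, a lower number a stronger inhibitor:
compound 1 `O=C1CCCC/C1=C\c1ccc([N+](=O)[O-])cc1` gives 46500 nM
compound 2 `CN(C)c1ccc(/C=C2\CCC/C(=C\c3ccccc3[N+](=O)[O-])C2=O)cc1` gives 164000 nM
compound 3 `CN(C)c1ccc(/C=C2\CCC/C(=C\c3cccc([N+](=O)[O-])c3)C2=O)cc1` gives 156000 nM

Compound 2 has the highest number of the three. Compound 3 sits closest, and the step of a 1.1-fold lower number from compound 2 to compound 3 (0.02 log units; within the scatter) lies within the scatter, so the two cannot be ordered. Compound 1 is furthest away, with the lower number, and that gap is beyond the scatter.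

Compound 4 `Cc1ccc(/C=C2\CCC/C(=C\c3ccccc3[N+](=O)[O-])C2=O)cc1` is not yet measured. It differs from compound 2 in one place: methyl in place of dimethylamino on an aromatic carbon

Among the compounds with values here, the only measured step, a 1.1-fold lower number from compound 2 to compound 3 (0.02 log units; within the scatter), concerns the nitrophenyl group on the other chain carbon and says nothing about the dimethylamino group. Within the data shown here, no measured pair isolates the change from dimethylamino to methyl, so there is no basis for expecting a step beyond the scatter in either direction. The expectation is therefore a number close to that of compound 2, with wide uncertainty.

For compound 4 the estimated value in this assay is 100000 nM, with a range from 30000 nM to 330000 nM. This expected result corresponds to the step of a 1.6-fold lower number from compound 2 to compound 4 (0.21 log units; within the scatter).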

Compound 4, half-maximal inhibitory concentration: 7770 nM
Beside the measured number, compound 4's estimate is 13-fold (1.11 log units) above it; the whole stated range lies above it.
By their numbers in this assay, from the lowest: compound 4; then compound 1; then compounds 3 and 2 (each within the scatter of the next).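

In this assay, the aromatic carbon para to a large group proves sensitive to substitution: methyl in place of dimethylamino gives a 21-fold lower number from compound 2 to compound 4 (1.32 log units; beyond the scatter), a large step. The only earlier step, a 1.1-fold lower number from compound 2 to compound 3 (0.02 log units; within the scatter), concerned the nitrophenyl group and lay within the scatter, so this is the first change in the series shown to move the number beyond it. The exchange replaces 3 heavy atoms (2 carbon, 1 nitrogen), including 1 hydrogen-bond acceptor, with 1 carbon atom, and no measurement bearing on the cause of the step is available.

Going by these compounds, this single pair cannot show whether the step comes from removing dimethylamino, from introducing methyl, or from both, and whether it would also appear with 3-nitrophenyl in place of 2-nitrophenyl remains open. A primary amine, a methoxy group or a chlorine atom on the same aromatic carbon, or a bare hydrogen there, would help to show whether dimethylamino stands apart or whether methyl does.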